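A few compounds are considered here, and "the series" means these few. Any claim that something is new, unique, unknown or untested is made for them only; others in the source may bear on it.

Measured compounds:
Compound 1 `CCCCc1nc(C(C)C)c(CC(=O)OC2CC2)c(=O)n1Cc1ccc(-c2ccccc2-c2noc(=O)[nH]2)cc1` gives 10.3% in an ADME assay on microsomes from liver (Homo sapiens) for metabolic stability, with a stated time of 30 min; a lower number here means that less of the compound is left, a higher number that more of the compound is left.
Compound 2 `CCCCc1nc(C(C)C)c(CC(=O)OC2CCCCC2)c(=O)n1Cc1ccc(-c2ccccc2-c2noc(=O)[nH]2)cc1` gives 13.3% in this assay.
Compound 3 `CCCCc1nc(C)c(CC(=O)OC2CC2)c(=O)n1Cc1ccc(-c2ccccc2-c2noc(=O)[nH]2)cc1` gives 34.5% in this assay.

Compound 3 stands highest of the three in this assay; the step of a number 24.2 percentage points higher from compound 1 to compound 3 (beyond the scatter) shows the core difference (methyl in place of isopropyl on an aromatic carbon). The step of a number 3 percentage points higher from compound 1 to compound 2 (within the scatter) shows the effect of cyclohexyl in place of cyclopropyl on an oxygen next to a carbonyl group.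

Compound 4 `CCCCc1nc(C)c(CC(=O)OC2CCCCC2)c(=O)n1Cc1ccc(-c2ccccc2-c2noc(=O)[nH]2)cc1` is not yet measured. It differs from compound 3 by cyclohexyl in place of cyclopropyl on an oxygen next to a carbonyl group; this is the same change as from compound 1 to compound 2, at the same place, on the core of compound 3. An essentially unchanged number is expected from compound 3 to compound 4, a number 2.5 percentage points higher from compound 3 to compound 4 (within the scatter), because a number 3 percentage points higher from compound 1 to compound 2 (within the scatter) lay within the scatter. Compound 4 is therefore estimated at 37% in this assay, with a range from 25% to 50%.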

Compound 4, percent of the compound remaining: 3.9%
Compound 4: the middle estimate sits 33.1 percentage points above what was measured; the whole stated range lies above it.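

The change to cyclohexyl in place of cyclopropyl on the oxygen gives a number 30.6 percentage points lower from compound 3 to compound 4 (beyond the scatter), so in this assay its effect does not carry over from the core of compound 1 to the core of compound 3: the same change on two cores in this assay, a number 3 percentage points higher (within the scatter) from compound 1 to compound 2 and a number 30.6 percentage points lower (beyond the scatter) from compound 3 to compound 4, 33.6 percentage points apart, beyond the scatter of two such steps

Methyl in place of isopropyl on an aromatic carbon likewise depends on the group on the oxygen, giving a number 9.4 percentage points lower from compound 2 to compound 4 (within the scatter) with cyclohexyl there: the same change on two cores in this assay, a number 24.2 percentage points higher (beyond the scatter) from compound 1 to compound 3 and a number 9.4 percentage points lower (within the scatter) from compound 2 to compound 4, 33.6 percentage points apart, beyond the scatter of two such steps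

The four compounds show that the two changes do not add up in this series, but they do not show why, and one pair per change does not predict the outcome on any further core.

Open, on these data alone, is whether a cyclopentyl or a tert-butyl group on the oxygen would follow compound 3 or compound 4. As far as these compounds go, an ethyl group on the aromatic carbon, or an amide in place of the ester, is equally open.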